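Piperidine substituent change in a mouse glucose tolerance read-out

The compounds below may be only part of what the source reports. "The series", "measured", "known", "first", "only" and "open" are said of these compounds alone.

Compound 1, `O=S1(=O)Cc2nc(-c3cc(F)c(Cl)cc3F)nc(N3CCC(CO)CC3)c2C1`, gives 0.3 mg/kg in a functional assay on the whole organism (blood, strain ICR) with Mus musculus as the target, in the glucose tolerance test, with a stated time of 30 min; on this read-out lower numbers stand for an effect already at smaller amounts and higher numbers for an effect only at larger amounts of compound.
Compound 2, `O=S1(=O)Cc2nc(-c3cc(F)c(Cl)cc3F)nc(N3CCC(CCO)CC3)c2C1`, gives 1 mg/kg in this assay.

Compound 2 has the highest of the two numbers; its closest neighbour is compound 1, and the step of a 3.3-fold higher number from compound 1 to compound 2 (0.52 log units; beyond the scatter) lies beyond the scatter. Compound 3, `CNC(=O)C1CCN(c2nc(-c3cc(F)c(Cl)cc3F)nc3c2CS(=O)(=O)C3)CC1`, has not been measured. It differs from compound 2 in one place: methylcarbamoyl in place of 2-hydroxyethyl on a saturated ring carbon.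

Among the compounds with values here, only one measured step is known, and it concerns lengthening of the hydroxy-bearing chain, not the methylcarbamoyl group, so it gives little guidance for this change. The leaving and entering groups are of similar size and each carries one hydrogen-bond donor and one acceptor. Compound 3 is therefore expected to remain close to compound 2, with a step of no change at the digits printed from compound 2 to compound 3 (within the scatter) not beyond the scatter. The estimate for compound 3 is 1 mg/kg, with a range from 0.3 mg/kg to 3 mg/kg.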

Compound 3, minimum effective dose in the Mus musculus assay: 3 mg/kg
Compound 3: the middle estimate sits 3.0-fold (0.48 log units) below what was measured, within the range that was stated.
By their numbers in the Mus musculus assay, from the lowest: compound 1; then compound 2; then compound 3.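

At this ring carbon, the count of hydrogen-bond donors and acceptors does not settle the outcome in the Mus musculus assay: methylcarbamoyl in place of 2-hydroxyethyl, with those counts unchanged, gives a 3.0-fold higher number from compound 2 to compound 3 (0.48 log units; beyond the scatter). Set against the hydroxymethyl group, the same amide gives a 10-fold higher number from compound 1 to compound 3 (1.00 log units; beyond the scatter), which places both hydroxy-bearing chains at lower numbers than methylcarbamoyl among these three compounds. In a physicochemical assay for solubility, with a stated time of 20 h, at pH 6.8 (a lower number here means a less soluble compound, a higher number a more soluble compound), compound 2 gives 23000 nM and compound 3 gives 11000 nM, with a 2.1-fold lower number from compound 2 to compound 3 (0.32 log units; beyond the scatter), but these compounds alone cannot show whether this gap is linked to the dose.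

Open, as far as these compounds go, is how an amine, a carboxylic acid or an unmethylated carboxamide at this ring carbon would compare with the hydroxymethyl group of compound 1. Also open, from the compounds shown here alone, is whether a longer chain ending in methylcarbamoyl would behave like compound 3.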